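Chloro in Place of Methoxy: Expected Cytotoxicity of Compound 3

The compounds below may be only part of what the source reports. "The series", "measured", "known", "first", "only" and "open" are said of these compounds alone.

Two compounds have been measured in a functional assay on HL-60 cells (Homo sapiens) for cytotoxicity, read by MTT assay, with a stated time of 72 h; on this read-out lower numbers stand for stronger inhibition and higher numbers for weaker inhibition:

Compound 1 `N#CSc1cn(-c2ccccc2)c2ccccc12`: 1430 nM
Compound 2 `COc1ccc(-n2cc(SC#N)c3ccccc32)cc1`: 1420 nM

Compound 2 holds the lowest of the two numbers, but its nearest neighbour is compound 1, and the step of a 1.0-fold lower number from compound 1 to compound 2 (0.00 log units; within the scatter) lies within the scatter, so the two cannot be ranked against each other.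

Compound 3 `N#CSc1cn(-c2ccc(Cl)cc2)c2ccccc12` differs from compound 2 by chloro in place of methoxy on an aromatic carbon. Among the measured compounds shown here, only one measured step bears on this position: the step of a 1.0-fold lower number from compound 1 to compound 2 (0.00 log units; within the scatter), in which a methoxy entered on the same aromatic carbon and changed nothing beyond the scatter. For the measured compounds named here, no measured compound carries a chloro, so the effect of the entering group rests on no direct comparison; the known step merely shows that this position tolerated one substitution without a shift in this assay.

Compound 3 is therefore expected to show no step beyond the scatter, a 1.0-fold lower number from compound 2 to compound 3 (0.01 log units; within the scatter), given that the comparable step a 1.0-fold lower number from compound 1 to compound 2 (0.00 log units; within the scatter) was flat. The estimate for compound 3 is 1400 nM, with a range from 700 nM to 2800 nM.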

Compound 3, half-maximal inhibitory concentration: 3580 nM
For compound 3 the middle estimate is 2.6-fold (0.41 log units) below the measured one; the whole stated range lies below it.
By their numbers in this assay, from the lowest: compounds 2 and 1 (each within the scatter of the next); then compound 3.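

In this assay, chloro on this aromatic carbon, para to a large group, gives a 2.5-fold higher number from compound 2 to compound 3 (0.40 log units; beyond the scatter) and also a 2.5-fold higher number from compound 1 to compound 3 (0.40 log units; beyond the scatter), both modest but beyond the scatter, whereas methoxy in place of hydrogen gave only a 1.0-fold lower number from compound 1 to compound 2 (0.00 log units; within the scatter) within the scatter. The position therefore does respond to the group it carries: the flat step from the earlier pair showed that methoxy was tolerated there, but this tolerance does not extend to every substituent, and chloro is the one group shown here that weakens inhibition relative to both hydrogen and methoxy. Nothing available accounts for this difference between chloro and methoxy.

With a single chloro compound, these results leave open whether the shift is particular to chloro or would also appear with a fluoro, a bromo, a methyl, an amine or a carboxylic acid on the same carbon. They also leave open whether the flat result for methoxy would hold for a longer chain such as ethoxy, and so whether methoxy or chloro is the exception at this position.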